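Bromo for chloro on the benzyl ring

A few compounds are considered here, and "the series" means these few. Any claim that something is new, unique, unknown or untested is made for them only; others in the source may bear on it.

Compound 3 `CC(C(=O)NCc1ccc(Cl)cc1)c1ccc(NS(C)(=O)=O)c(F)c1` in a functional assay on CHO cells for antagonist activity at transient receptor potential cation channel subfamily V member 1 (Rattus norvegicus) (a lower number here means a stronger inhibitor, a higher number a weaker inhibitor), gives 367 nM. Compound 1 `CC(C)(C)c1ccc(CNC(=O)C(C)(C)c2ccc(NS(C)(=O)=O)c(F)c2)cc1` in this assay gives 467 nM, and compound 2 `COc1cc(C2(C(=O)NCc3ccc(C(C)(C)C)cc3)CC2)ccc1NS(C)(=O)=O` in this assay gives 2250 nM. Of these three numbers compound 3 carries the lowest, with compound 1 within the scatter of it and compound 2 beyond it. Compound 4 `CC(C(=O)NCc1ccc(Br)cc1)c1ccc(NS(C)(=O)=O)c(F)c1` differs from compound 3 by bromo in place of chloro on an aromatic carbon. Within the data shown here, no measured pair shows this exchange, so its size cannot be read from the data. For compound 4 the expected step is none beyond the scatter, in either direction, the step from compound 3 to compound 4 being estimated as a 1.1-fold lower number from compound 3 to compound 4 (0.03 log units; within the scatter). Compound 4 is accordingly expected near 340 nM, within 150 nM to 800 nM.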

Compound 4, inhibition constant: 250 nM
For compound 4 the middle estimate is 1.4-fold (0.13 log units) above the measured one, and the stated range covers the measured number.
By their numbers in this assay, from the lowest: compounds 4, 3 and 1 (each within the scatter of the next); then compound 2.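

Among these compounds, the first measured exchange at this position, 4-chlorobenzyl to 4-bromobenzyl, gives a 1.5-fold lower number from compound 3 to compound 4 (0.17 log units; within the scatter) in this assay. Among the compounds shown here, the position therefore accepts bromo as well as chloro, with no step that can be told from repeat measurement. Nothing available bears on a cause for this result.

Going by these compounds, whether an amine or a carboxylic acid would be accepted at this position stays open. The tert-butyl group of compound 1 cannot be set against either halogen, since compound 1 also differs from compound 3 elsewhere.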